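Working notes: ring groups on the shared core

A few compounds are considered here, and "the series" means these few. Any claim that something is new, unique, unknown or untested is made for them only; others in the source may bear on it.

Measured in a physicochemical assay for lipophilicity, using the shake flask method, measured as octanol-water partition, at pH 7.4; on this read-out higher numbers stand for higher lipophilicity and lower numbers for lower lipophilicity:
- compound 1 `CC(=O)N[C@@H]1CCC[C@H](C(=O)Nc2cc(-c3cnn4ccccc34)c(Cl)cn2)C1`: 3.6
- compound 2 `CC(=O)N[C@@H]1CCC[C@H](C(=O)Nc2cc(-c3cnc4n3CCCC4)c(Cl)cn2)C1`: 2.7
- compound 3 `CC(=O)N[C@@H]1CCC[C@H](C(=O)Nc2cc(-c3nnn4ccccc34)c(Cl)cn2)C1`: 2

Compound 3 stands lowest of the three at 2, and its steps to both others lie beyond the scatter. The change to compound 4 `CC(=O)N[C@@H]1CCC[C@H](C(=O)Nc2cc(-c3cnn4c3CCCCC4)c(Cl)cn2)C1` is a group of 10 heavy atoms (8 carbon, 2 nitrogen; one five-membered aromatic ring with 2 hetero atoms, one seven-membered non-aromatic ring with 1 hetero atom) in place of a group of 9 heavy atoms (6 carbon, 3 nitrogen; one five-membered aromatic ring with 3 hetero atoms, one six-membered aromatic ring with 1 hetero atom), on an aromatic carbon, opposite the ring nitrogen. The closest guide is compound 2, which also carries a five-membered aromatic ring with 2 hetero atoms and a non-aromatic ring. The modest a number 0.70 log units lower from compound 2 to compound 3 (beyond the scatter) therefore bears most directly, beside the large a number 1.60 log units lower from compound 1 to compound 3 (beyond the scatter) and the modest a number 0.90 log units lower from compound 1 to compound 2 (beyond the scatter). Among the compounds with values here, no measured step covers a seven-membered non-aromatic ring. A modest upward step is expected, estimated as a number 1.00 log units higher from compound 3 to compound 4 (beyond the scatter). The estimate for compound 4 is 3, with an expected range from 2.5 to 3.5.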

Compound 4, distribution coefficient: 3.6
Compound 4: the middle estimate sits 0.60 log units below what was measured; the whole stated range lies below it.
By their numbers in this assay, from the lowest: compound 3; then compound 2; then compounds 1 and 4 (each within the scatter of the next).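

In this assay, a non-aromatic ring in the group on this aromatic carbon does not by itself hold the number down: the seven-membered ring group gives a number 0.90 log units higher from compound 2 to compound 4 (beyond the scatter), and against the triazole-type group of compound 3 it gives a number 1.60 log units higher from compound 3 to compound 4 (beyond the scatter). With no change at the digits printed from compound 1 to compound 4 (within the scatter), it stands level with the fully aromatic group of compound 1. Nothing available explains these steps.

The ring size cannot be separated from the different arrangement of the two groups. From the compounds shown here alone, whether a morpholine at this place would sit nearer compound 3 or compound 4 remains open.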